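The source may report more compounds than this note shows. Statements on the series, on what has been measured and on what is new or still open speak of the compounds shown alone.

Working notes on the series. Two compounds have numbers in an assay on mitochondria from liver for inhibition of kynurenine 3-monooxygenase (Mus musculus), read by LC-MS, with stated times of 5 min and 30 min (a lower number here means a stronger inhibitor, a higher number a weaker inhibitor), so far. Compound 1 `Cc1ccc(S(=O)(=O)Nc2ccc(-c3ccc(N(C)C)cc3)nn2)cc1` gives 546 nM in this assay. Compound 2 `Cc1ccc(S(=O)(=O)Nc2ccc(-c3ccccc3N3CCCC3)nn2)cc1` gives 1.7 nM in this assay, the lower of the two numbers, and the gap between compound 1 and compound 2 is well beyond the scatter. Among the measured compounds shown here, the two differ in more than one place, so no single step can be read from them; their two values show only that compound 2 is the stronger inhibitor of the pair.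

Compound 3 `Cc1ccc(S(=O)(=O)Nc2ccc(-c3ccccc3N3CCN(C)CC3)nn2)cc1` has not been measured in this assay. It differs from compound 2 in one place: 4-methylpiperazin-1-yl in place of pyrrolidin-1-yl on an aromatic carbon. For the measured compounds named here, no step between two measured compounds covers this change, so the expectation rests on the value of compound 2 alone. The step is expected to be modest and to run toward a higher number, as given by a 3.5-fold higher number from compound 2 to compound 3 (0.55 log units; beyond the scatter), a shift that stays close to the scatter rather than far beyond it. For compound 3 the estimated value in this assay is 6 nM, with a range from 1.5 nM to 30 nM.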

Compound 3, half-maximal inhibitory concentration: > 100 nM
Compound 3: only a limit was reported; the forecaster's own chance of this, stated with the estimate: 2%; middle value at least 16-fold (1.22 log units) from the limit.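

In this assay compound 3 gives > 100 nM, which is a limit of the assay and not a number. On this aromatic carbon, ortho to a large group, the low number of compound 2 does not carry over when 4-methylpiperazin-1-yl replaces pyrrolidin-1-yl, with an at least 58-fold higher number from compound 2 to compound 3 (1.76 log units; beyond the scatter), so this position is clearly sensitive to the identity of the ring amine placed there. The step is large but gives only a lower bound on the change, and its full size cannot be read: the limit of > 100 nM in this assay, at which 1 of the 3 values shown sits.

The compounds shown do not separate the parts of this change, as ring size, the second ring nitrogen and its methyl group all enter together, and no cause for the loss can be assigned from these data; piperidin-1-yl or morpholin-4-yl at the same place would bear on that question. As far as these compounds go, it also remains open whether unsubstituted piperazin-1-yl or a smaller open-chain amine such as dimethylamino on this same carbon would stay near compound 2 or move toward compound 3.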